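Benzylsulfanyl for bromo on the biphenyl series

The compounds below may be only part of what the source reports. "The series", "measured", "known", "first", "only" and "open" are said of these compounds alone.

Of the compounds shown here, two carry numbers so far. In an assay on isolated protein (Sus scrofa) for inhibition of 2-Hydroxyacid oxidase 1 (Homo sapiens) (a higher number here means a weaker inhibitor, a lower number a stronger inhibitor), compound 1 `CCCCCCCCCc1ccc(C(=O)CC(=O)C(=O)O)cc1` gives 600 nM. In this assay compound 2 `O=C(O)C(=O)CC(=O)c1ccc(-c2ccc(Br)cc2)cc1` gives 63 nM, the lowest of the two numbers, with compound 1 standing well beyond the scatter above it. The two differ in more than one place, so their values are taken only as they stand.

Compound 3 `O=C(O)C(=O)CC(=O)c1ccc(-c2ccc(SCc3ccccc3)cc2)cc1` has not been measured in this assay. It departs from compound 2 by one change, (benzylsulfanyl in place of bromo on an aromatic carbon), a benzylsulfanyl in place of bromo on an aromatic carbon. For the measured compounds named here, no measured pair shows this kind of change, so the direction is open. The expected step from compound 2 to compound 3 is a 1.3-fold higher number from compound 2 to compound 3 (0.10 log units; within the scatter), not beyond the scatter. For compound 3 in this assay the estimate is 80 nM, with a range from 20 nM to 320 nM.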

Compound 3, half-maximal inhibitory concentration: 400 nM
The estimate for compound 3 lay 5.0-fold (0.70 log units) below the measured number, outside the stated range (above it).
By their numbers in this assay, from the lowest: compound 2; then compounds 3 and 1 (each within the scatter of the next).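

The first step read at this place is a 6.3-fold higher number from compound 2 to compound 3 (0.80 log units; beyond the scatter) in this assay, with benzylsulfanyl in place of bromo on an aromatic carbon para to a large group. The place therefore responds to the identity of its substituent, and this larger group, with its sulfur and added six-membered aromatic ring, comes with a higher number rather than a lower one. A single pair gives only this one direction and sets no trend for the series. No measurement offered here accounts for the step, and the sulfur, the methylene link and the added ring all change together in this one replacement.

Open, as far as these compounds go, is which part of benzylsulfanyl goes with the higher number, a question that benzyloxy or phenyl at the same place would separate. Also open, from the compounds shown here alone, is how chloro, methoxy or an amine would compare with bromo there.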